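The source may report more compounds than this note shows. Statements on the series, on what has been measured and on what is new or still open speak of the compounds shown alone.

In a functional assay on HL-60 cells (Homo sapiens) for cytotoxicity, read by luminescence and CellTiter-Glo, with a stated time of 3 days (a lower number here means a stronger inhibitor, a higher number a weaker inhibitor), compound 1 (`O=C(Nc1cc(C(F)(F)F)cc(C(F)(F)F)c1)c1cc(Cl)c(F)cc1O`) gives 430 nM and lies within the scatter of both other measured compounds. Compound 2 (`Cc1cc(C#N)ccc1NC(=O)c1ccc2cccnc2c1O`) reads 710 nM and compound 3 (`O=C(Nc1cc(C(F)(F)F)cc(C(F)(F)F)c1)c1cc(Br)c(F)cc1O`) reads 250 nM alongside it. Compound 4 (`O=C(Nc1cc(C(F)(F)F)cc(C(F)(F)F)c1)c1cc(Cl)c(-c2ccccc2)cc1O`) has not yet been measured. It differs from compound 1 by phenyl in place of fluoro on an aromatic carbon with phenyl in place of fluoro on an aromatic carbon. Among the compounds with values here, the only measured step (a 1.7-fold lower number from compound 1 to compound 3 (0.24 log units; within the scatter)) replaces chloro with bromo, and no measured step touches the fluoro group. The data therefore give no direction, and no step beyond the scatter is expected in this assay, although the uncertainty is wide. The expected step is small (a 1.0-fold higher number from compound 1 to compound 4 (0.02 log units; within the scatter)). For compound 4 the estimated value is 450 nM with an expected range (130 nM to 1500 nM).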

Compound 4, half-maximal inhibitory concentration: 790 nM
The estimate for compound 4 lay 1.8-fold (0.24 log units) below the measured number; the range from low to high includes it.
By their numbers in this assay, from the lowest: compounds 3, 1, 2 and 4 (each within the scatter of the next, the first and the last beyond it).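

In this assay, phenyl in place of fluoro on this aromatic carbon, ortho to a chloro group and meta to a hydroxy group, stays within the scatter (a 1.8-fold higher number from compound 1 to compound 4 (0.26 log units; within the scatter)). This position therefore takes a six-membered aromatic ring of six heavy atoms in place of a single fluorine without a step beyond the scatter. Nothing available accounts for this result. Going by these compounds, whether an amine, a carboxylic acid or a longer chain on this carbon would also stay within the scatter remains open.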